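Predicting a Chloro-for-Fluoro Swap on a Thiazole Acylurea

This account rests on a few compounds, and the source may have more. Where it says the series, first, only, none or still open, it means among the compounds named here.

Measured compounds:
Compound 1, `CN(C(=O)NC(=O)c1ccc(F)c(F)c1)c1nc(C(F)(F)F)c(C(=O)N/N=C/c2ccc(C(F)(F)F)cc2)s1`, gives 5.93 ug/mL in a functional assay on MCF7 cells (Homo sapiens) for inhibition, read by MTT assay, with a stated time of 72 h; on this read-out higher numbers stand for weaker inhibition and lower numbers for stronger inhibition.
Compound 2, `CN(C(=O)NC(=O)c1ccc(Cl)cc1Cl)c1nc(C(F)(F)F)c(C(=O)N/N=C/c2ccc(C(F)(F)F)cc2)s1`, gives 8.42 ug/mL in this assay.
Compound 3, `CN(C(=O)NC(=O)c1ccc(F)c(F)c1)c1nc(C(F)(F)F)c(C(=O)N/N=C/c2cc(C(F)(F)F)cc(C(F)(F)F)c2)s1`, gives 2.61 ug/mL in this assay.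

The change 2,4-dichlorophenyl in place of 3,4-difluorophenyl on a carbonyl carbon has already been made once, and it produced a 1.4-fold higher number from compound 1 to compound 2 (0.15 log units; within the scatter). How the core of compound 3 differs from that of compound 1 is not broken down here. Compound 4, `CN(C(=O)NC(=O)c1ccc(Cl)cc1Cl)c1nc(C(F)(F)F)c(C(=O)N/N=C/c2cc(C(F)(F)F)cc(C(F)(F)F)c2)s1`, carries the same change on the core of compound 3: 2,4-dichlorophenyl in place of 3,4-difluorophenyl on a carbonyl carbon. The surroundings of the altered carbonyl carbon read the same in both cases, so this is the same change. It is expected to give roughly the same small step, a 1.4-fold higher number from compound 3 to compound 4 (0.15 log units; within the scatter), because the earlier case showed a 1.4-fold higher number from compound 1 to compound 2 (0.15 log units; within the scatter), which lies within the scatter. Compound 4 is therefore estimated at 3.7 ug/mL in this assay, expected to fall between 2.2 ug/mL and 6.5 ug/mL.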

Compound 4, half-maximal inhibitory concentration: > 100 ug/mL
Compound 4 ended at the assay's limit; the forecaster's own chance of this, stated with the estimate: 2%; middle value at least 27-fold (1.43 log units) away from the limit.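

In this assay compound 4 gives > 100 ug/mL as its reading, which is a limit of the assay and not a number: the limit of > 100 ug/mL in this assay, at which 1 of the 4 values shown sits.

The swap of 3,4-difluorophenyl for 2,4-dichlorophenyl therefore gave an at least 38-fold higher number from compound 3 to compound 4 (1.58 log units; beyond the scatter) on the core of compound 3, and its effect did not carry over unchanged from the core of compound 1: the same change on two cores in this assay, a 1.4-fold higher number (0.15 log units; within the scatter) from compound 1 to compound 2 and an at least 38-fold higher number (1.58 log units; beyond the scatter) from compound 3 to compound 4, at least 26-fold (1.43 log units) apart, beyond the scatter of two such steps.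

These two pairs do not show the true size of the larger step, which part of the core of compound 3 is responsible, or any rule for other cores.

As far as these compounds go, it remains open whether a 2,4-difluorophenyl or a 3,4-dichlorophenyl group on the core of compound 3 would read like compound 3 or like compound 4. Also open, from the compounds shown here alone, is how an unsubstituted phenyl group would read there.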